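The source may hold more compounds than are shown below. What is called first, only, known or untested is meant among the compounds shown, and "the series" means these compounds.

This account follows a single change at the ring that sits on the amide-type nitrogen of a shared core. In an in vitro functional assay on HEK293-A cells for positive allosteric modulation of metabotropic glutamate receptor 5 (Homo sapiens), read by FLIPR and calcium flux (on this read-out higher numbers stand for an effect only at larger amounts of compound and lower numbers for an effect already at smaller amounts), compound 1 `O=C1CC(c2nc(-c3cccc(Cl)c3)no2)CN1c1ccc(Cl)cc1` gives 140 nM. Compound 2 `Cc1ccc(N2CC(c3nc(-c4cccc(C(F)(F)F)c4)no3)CC2=O)cc1` gives 3400 nM in this assay. Compound 3 `Cc1cccc(N2CC(c3nc(-c4cccc(Cl)c4)no3)CC2=O)c1` reaches only the limit of this assay, > 10000 nM, so for compound 3 no number is known, only a bound, and it stands at the upper edge of the values shown (the limit of > 10000 nM in this assay, at which 1 of the 3 values shown sits). Among the measured compounds shown here, the one measured step that bears on this region is an at least 71-fold higher number from compound 1 to compound 3 (1.85 log units; beyond the scatter), a large loss of effect. Compound 4 `O=C1CC(c2nc(-c3cccc(Cl)c3)no2)CN1c1cccc(Cl)c1` differs from compound 3 by chloro in place of methyl on an aromatic carbon. Because compound 3 sits at a limit, the step to compound 4 cannot be measured from the data shown, and the large step from compound 1 to compound 3 shows that this assay answers strongly to changes of this ring. Compound 4 is expected to give about 5000 nM, within 1000 nM and 20000 nM. The expected step is therefore an at least 2.0-fold lower number from compound 3 to compound 4 (0.30 log units; that floor lies within the scatter).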

Compound 4, half-maximal effective concentration: > 10000 nM
Compound 4: only a limit was reported; the forecaster's own chance of this, stated with the estimate: 40%; middle value at least 2.0-fold (0.30 log units) from the limit.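

Exchanging 4-chlorophenyl for 3-chlorophenyl on the amide-type nitrogen gives an at least 71-fold higher number from compound 1 to compound 4 (1.85 log units; beyond the scatter) in this assay, so the loss seen with 3-methylphenyl in compound 3 also appears when the group on the ring is chloro. Compound 3 and compound 4 both stand at a limit, so the step between them cannot be read, and the exchange of methyl for chloro shows no readable gain. Compound 3 and compound 4 therefore sit together at the upper edge of the values shown: the limit of > 10000 nM in this assay, at which 2 of the 4 values shown sit.

From the compounds shown here alone, it stays open how a methoxy group, an amine or a nitrile in place of the chloro of compound 1 would read. Compound 2 differs from compound 1 in more than one place, so it cannot settle what a 4-methylphenyl alone does.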